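The compounds below may be only part of what the source reports. "The series", "measured", "known", "first", "only" and "open" are said of these compounds alone.

Three compounds sharing one core have been measured in a functional assay on the whole organism with Mus musculus as the target, in the maximal electroshock model, with a stated time of 1 h; a lower number here means that less compound is needed, a higher number that more compound is needed for the effect:
compound 1 `CC(C)N(N)c1nnc(-c2ccccc2Cl)s1` gives 54 mg/kg
compound 2 `COCN(N)c1nnc(-c2ccccc2Cl)s1` gives 50 mg/kg
compound 3 `NN(Cc1ccccc1)c1nnc(-c2ccccc2Cl)s1` gives 186 mg/kg

On these numbers compound 2 sits at the low end, but its nearest neighbour is compound 1, and that step, a 1.1-fold lower number from compound 1 to compound 2 (0.03 log units; within the scatter), is too small to rank the two. Only compound 3 stands apart, through a 3.4-fold higher number from compound 1 to compound 3 (0.54 log units; beyond the scatter) and a 3.7-fold higher number from compound 2 to compound 3 (0.57 log units; beyond the scatter).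

Compound 4 `CC(C)NNc1nnc(-c2ccccc2Cl)s1` differs from compound 2 in a single place: (isopropylamino)amino in place of amino(methoxymethyl)amino on an aromatic carbon. The entering and leaving groups hold the same count of heavy atoms, and an isopropyl group is already present in compound 1, though arranged differently on its pair of nitrogens.

Among the compounds with values here, no measured step matches this rearrangement exactly. The step from compound 1 to compound 2 shows that exchanging isopropyl for methoxymethyl on the ring nitrogen left this assay unchanged within the scatter, while the two steps to compound 3 show that only the much larger benzyl group produced a modest rise. On that basis compound 4 is expected to stay close to compound 2, with a step of about a 1.2-fold higher number from compound 2 to compound 4 (0.06 log units; within the scatter), not beyond the scatter. The estimate for compound 4 in this assay is therefore 58 mg/kg, within a range from 25 mg/kg to 130 mg/kg.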

Compound 4, dose for half-maximal effect: 50 mg/kg
Compound 4: middle estimate off by 1.2-fold (0.06 log units), on the high side, and the stated range covers the measured number.
By their numbers in this assay, from the lowest: compounds 2, 4 and 1 (each within the scatter of the next); then compound 3.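

Compound 4 places the isopropyl group differently from compound 1: in every earlier compound the group sat on the nitrogen on the aromatic ring, and here it forms (isopropylamino)amino instead, yet a 1.1-fold lower number from compound 1 to compound 4 (0.03 log units; within the scatter) in this assay shows that this rearrangement leaves the number within the scatter. The exchange of amino(methoxymethyl)amino for (isopropylamino)amino gives no change at the digits printed from compound 2 to compound 4 (within the scatter), even though the leaving group has 1 hydrogen-bond donor and 3 hydrogen-bond acceptors and the entering group has 2 of each, so this assay does not separate these groups of equal heavy-atom count. Nothing available explains why these three groups read alike.

The compounds shown leave open whether (benzylamino)amino would give a number like the one for compound 3, at 186 mg/kg, or would stay with the other three compounds. They also leave open how a much longer chain, such as n-octyl, or a carboxylic acid on the same nitrogen would read in this assay.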